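Cytotoxicity of tetradecyl amide imines: nitrophenyl positional swap

A few compounds are considered here, and "the series" means these few. Any claim that something is new, unique, unknown or untested is made for them only; others in the source may bear on it.

Measured compounds in an ADME assay on HEK293 cells (Homo sapiens) for cytotoxicity; on this read-out higher numbers stand for weaker inhibition and lower numbers for stronger inhibition:
compound 1 `CCCCCCCCCCCCCCNC(=O)[C@H](CO)/N=C/c1cccc([N+](=O)[O-])c1`, 82700 nM
compound 2 `CCCCCCCCCCCCCCNC(=O)[C@H](CO)/N=C/c1ccccc1C`, 81100 nM

Compound 1 gives the highest of the two numbers in this assay, and compound 2 sits nearest to it, with a 1.0-fold lower number from compound 1 to compound 2 (0.01 log units; within the scatter), so the two values cannot be ordered against each other. Within the data shown here, the only measured step at the aryl group on the carbon with a double bond to nitrogen is a 1.0-fold lower number from compound 1 to compound 2 (0.01 log units; within the scatter), where 2-methylphenyl replaces 3-nitrophenyl without moving the number beyond the scatter.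

Compound 3 `CCCCCCCCCCCCCCNC(=O)[C@H](CO)/N=C/c1ccccc1[N+](=O)[O-]` is not yet measured. It differs from compound 1 as follows: 2-nitrophenyl in place of 3-nitrophenyl on a carbon with a double bond to nitrogen. Among the measured compounds shown here, no measured pair shows a nitro group moved between these two positions, so the step from compound 1 to compound 2 bears on it only as far as it shows the aryl group tolerating a change without a shift beyond the scatter. On that basis no step beyond the scatter is expected, and compound 3 is estimated at 80000 nM, with a range from 40000 nM to 160000 nM, which means an expected 1.0-fold lower number from compound 1 to compound 3 (0.01 log units; within the scatter).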

Compound 3, half-maximal inhibitory concentration: 82600 nM
Beside the measured number, compound 3's estimate is 1.0-fold (0.01 log units) below it; low and high end bracket the measured number.
By their numbers in this assay, from the lowest: compounds 2, 3 and 1 (each within the scatter of the next).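

In this assay, the exchange of 3-nitrophenyl for 2-nitrophenyl on the carbon with a double bond to nitrogen now has a direct reading, with a 1.0-fold lower number from compound 1 to compound 3 (0.00 log units; within the scatter) as the step, so the two nitrophenyl isomers cannot be told apart on this read-out. Nitro in place of methyl on an aromatic carbon gives a 1.0-fold higher number from compound 2 to compound 3 (0.01 log units; within the scatter) and adds a second step within the scatter, so all three aryl groups in compound 1, compound 2 and compound 3 are indistinguishable here, and the tolerance seen earlier for one exchange now extends to a change of nitro position and a change of the group itself. No separate data bear on why these values coincide.

From the compounds shown here alone, it remains open whether this insensitivity would hold with a more different aryl substituent on the same carbon, such as an amine or a carboxylic acid. Going by these compounds, the tetradecyl chain, the hydroxymethyl group and the amide are shared by compound 1, compound 2 and compound 3, so the effect on the read-out of a shorter chain, a longer chain or a replacement of that hydroxyl remains unknown.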